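The source may hold more compounds than are shown below. What is called first, only, known or untested is meant among the compounds shown, and "the series" means these compounds.

The measured compounds in a functional assay on PC-3 cells (Homo sapiens) for cytotoxicity, read by MTT assay, with a stated time of 24 h; a lower number here means a stronger inhibitor, a higher number a weaker inhibitor:
compound 1 `O=C1/C(=C/c2ccccc2F)CN(C(=S)SCc2cn(Cc3ccc(F)cc3)nn2)C/C1=C\c1ccccc1F`: > 80000 nM
compound 2 `O=C1/C(=C/c2ccccc2F)CN(Cc2cn(Cc3ccc(F)cc3)nn2)C/C1=C\c1ccccc1F`: 19400 nM

Compound 1 gives only a limit of this assay, > 80000 nM, so no number is known for it; this is the limit of > 80000 nM in this assay, at which 1 of the 2 values shown sits. Within the data shown here, compound 2 is the one compound with a measured number, 19400 nM, and so it is the only point of comparison for anything new built on the shared core. Compound 3 `O=C1/C(=C/c2ccccc2F)CN(Cc2cn(Cc3ccccc3F)nn2)C/C1=C\c1ccccc1F` is not yet measured. It keeps the same atoms as compound 2 and joins them differently: 2-fluorophenyl in place of 4-fluorophenyl on a saturated chain carbon bound to an aromatic nitrogen. Put another way, a 4-fluorobenzyl group becomes a 2-fluorobenzyl group, and nothing else on the shared core changes. Among the measured compounds shown here, no measured pair shows what this exchange does, so the expectation has to rest on compound 2 alone. The change is small, and the expected step from compound 2 to compound 3 in this assay is a 1.0-fold lower number from compound 2 to compound 3 (0.01 log units; within the scatter), which is not expected to reach beyond the usual scatter. Compound 3 is therefore expected to give about 19000 nM in this assay, with a likely range from 8000 nM to 50000 nM.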

Compound 3, half-maximal inhibitory concentration: 19700 nM
The estimate for compound 3 lay 1.0-fold (0.02 log units) below the measured number; the measured number falls inside the stated range.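

Among these compounds, until now, compound 2 was the only compound with a number in this assay, so nothing showed how this assay responds to a change at this position. Exchanging 4-fluorophenyl for 2-fluorophenyl on a saturated chain carbon bound to an aromatic nitrogen now gives a 1.0-fold higher number from compound 2 to compound 3 (0.01 log units; within the scatter), so for this one pair, moving the fluorine around the ring leaves a difference that repeated measurements could not tell apart from noise. Nothing measured here explains why compound 2 and compound 3 read alike.

Going by these compounds, this single pair says nothing about what would happen if the fluorophenyl ring gave way to a different kind of group, such as an amine, a carboxylic acid or a longer chain, so how far this position tolerates a real change in the group remains open. Compound 1 stays a limit rather than a number, so any step to it cannot be read: the limit of > 80000 nM in this assay, at which 1 of the 3 values shown sits.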